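The source may report more compounds than this note shows. Statements on the series, on what has been measured and on what is new or still open speak of the compounds shown alone.

Measured compounds:
compound 1, `C=CS(=O)(=O)N1CCN(c2ncnc3sc(-c4ccc(OC)cc4)cc23)CC1`, 29900 nM in a functional assay on MDA-MB-231 cells (Homo sapiens) for antiproliferative activity, read by MTT assay, with a stated time of 48 h; a higher number here means a weaker inhibitor, a lower number a stronger inhibitor
compound 2, `C=CS(=O)(=O)N1CCN(c2ncnc3sc(-c4ccnc(Cl)c4)cc23)CC1`, 27700 nM in this assay

Among the compounds with values here, compound 2 holds the lower of the two numbers in this assay, but its only neighbour is compound 1, with a 1.1-fold lower number from compound 1 to compound 2 (0.03 log units; within the scatter), so the two sit within the scatter. Compound 3, `C=CS(=O)(=O)N1CCN(c2ncnc3sc(-c4cn(C)nc4C(F)(F)F)cc23)CC1`, differs from compound 2 by 1-methyl-3-(trifluoromethyl)-1H-pyrazol-4-yl in place of 2-chloropyridin-4-yl on an aromatic carbon. Within the data shown here, the one step that bears on this is the earlier swap of the aryl group at the same position, from compound 1 to compound 2, which stayed within the scatter. A step of a 1.1-fold lower number from compound 2 to compound 3 (0.03 log units; within the scatter) is therefore expected, with no clear direction. Compound 3 is estimated at 26000 nM, between 8000 nM and 85000 nM.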

Compound 3, half-maximal inhibitory concentration: 10400 nM
Compound 3: the middle estimate sits 2.5-fold (0.40 log units) above what was measured; the measured number falls inside the stated range.
By their numbers in this assay, from the lowest: compound 3; then compounds 2 and 1 (each within the scatter of the next).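

In this assay this position, on an aromatic carbon next to the ring sulfur, proves able to move the number, with a 2.7-fold lower number from compound 2 to compound 3 (0.43 log units; beyond the scatter) and a 2.9-fold lower number from compound 1 to compound 3 (0.46 log units; beyond the scatter) as modest steps. Compound 1 and compound 2, both carrying six-membered aromatic rings here, had shown no such separation. Only the five-membered 1-methyl-3-(trifluoromethyl)-1H-pyrazol-4-yl has gone beyond the scatter so far.

From the compounds shown here alone, whether the ring or its trifluoromethyl group carries the step stays open, as does what a 1-methylpyrazol-4-yl lacking trifluoromethyl, or an aryl group bearing an amine, would give. Nothing available explains the step.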